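The compounds below may be only part of what the source reports. "The series", "measured", "known", "first", "only" and "open" are said of these compounds alone.

Among the measured compounds shown here, compound 2 `CS(=O)(=O)Nc1ccc2c(c1)S(=O)(=O)N=C(C1=C(O)C3CCCC3N(CCC3CC3)C1=O)N2` stands highest of the two numbers so far in an in vitro ADME assay on microsomes from liver (Homo sapiens) for metabolic stability; a lower number here means that the compound disappears faster, a higher number that the compound lasts longer: compound 2 gives 0.417 h, whereas compound 1 `CC(C)CCN1C(=O)C(C2=NS(=O)(=O)c3cc(NS(C)(=O)=O)ccc3N2)=C(O)C2CCCC21` gives 0.167 h, a step of a 2.5-fold higher number from compound 1 to compound 2 (0.40 log units; beyond the scatter). Compound 3 `CS(=O)(=O)Nc1ccc2c(c1)S(=O)(=O)N=C(C1=C(O)C3CCCC3N(Cc3ccccc3)C1=O)N2` differs from compound 2 by phenyl in place of cyclopropylmethyl on a saturated chain carbon bound to an amide-type nitrogen in a ring. For the measured compounds named here, the one measured step also altered the same chain, yet through a different exchange, so it bears only loosely on this one and gives no direction. The expected step is therefore a 1.2-fold lower number from compound 2 to compound 3 (0.08 log units; within the scatter), no more than the scatter. Compound 3 is estimated at 0.35 h, with a range from 0.15 h to 0.8 h.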

Compound 3, half-life: 0.833 h
Beside the measured number, compound 3's estimate is 2.4-fold (0.38 log units) below it; measured number outside the range, above it.
By their numbers in this assay, from the lowest: compound 1; then compounds 2 and 3 (each within the scatter of the next).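

Phenyl in place of cyclopropylmethyl on a saturated chain carbon bound to an amide-type nitrogen in a ring gives a 2.0-fold higher number from compound 2 to compound 3 (0.30 log units; within the scatter) in this assay, so an aromatic ring at this place cannot be told apart from the cyclopropyl-bearing chain. Phenyl in place of isobutyl gives a 5.0-fold higher number from compound 1 to compound 3 (0.70 log units; beyond the scatter), which leaves the isobutyl compound as the only one set apart beyond the scatter from both others. Nothing measured here explains these differences. Still open, from the compounds shown here alone, is how an amine or a carboxylic acid on the benzyl ring would read in this assay. Going by these compounds, a longer chain carrying the phenyl also remains open.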